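Phenoxy for Cyclohexyl on a Chain Ester Series

This account rests on a few compounds, and the source may have more. Where it says the series, first, only, none or still open, it means among the compounds named here.

Of the compounds shown here, two have been measured in a functional assay on HBL-100 cells (Homo sapiens) for inhibition, read by sulforhodamine B assay, with a stated time of 48 h; a lower number here means a stronger inhibitor of growth, a higher number a weaker inhibitor of growth. Compound 1 `O=C(CCCCC1CCCCC1)OCC1COCCOCCOCCOCCO1` gives only a limit there, > 100000 nM, and not a number; it sits at the limit of > 100000 nM in this assay, at which 1 of the 2 values shown sits. Going by the values given here, compound 2 `O=C(CCCCC1CCCCC1)OCC1COCCOCCOCCOCCOCCO1` gives 72000 nM in this assay, and this is the only number measured so far. Among the compounds with values here, the single further value shown is the limit of compound 1. Within the data shown here, no step between two measured compounds is available, so nothing about compound 2 can be ranked against another number.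

Compound 3 `O=C(CCCCOc1ccccc1)OCC1COCCOCCOCCOCCOCCO1` differs from compound 2 by phenoxy in place of cyclohexyl on a saturated chain carbon, four bonds along the chain from a carbonyl carbon. Among the measured compounds shown here, with no measured step of this kind to lean on, the writer expects the change to leave growth inhibition within the usual scatter, and the step he expects is a 1.0-fold higher number from compound 2 to compound 3 (0.02 log units; within the scatter). Compound 3 is thus estimated at 75000 nM in this assay, with an expected range from 25000 nM to 200000 nM.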

Compound 3, concentration for 50% growth inhibition: > 100000 nM
Compound 3 was reported as a limit (the forecaster's own chance of this, stated with the estimate: 35%); at least 1.3-fold (0.12 log units) between middle value and limit.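

Going by these compounds alone, this is the first step read at this position, on a saturated chain carbon, four bonds along the chain from a carbonyl carbon. In this assay, as far as these compounds go, phenoxy in place of cyclohexyl gives an at least 1.3-fold higher number from compound 2 to compound 3 (0.14 log units; that floor lies within the scatter), so the change brought no lower number, though only a floor can be read and the true size of the step remains unknown. The result for compound 3 is a limit and not a number: the limit of > 100000 nM in this assay, at which 2 of the 3 values shown sit.

Within the data shown here, the single step cannot separate the aromatic ring from the added oxygen, so it remains open whether phenyl at the same place, without that oxygen, would read differently. From the compounds shown here alone, it also remains open whether an amine, a carboxylic acid or a longer chain there would give a measurable number in this assay.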